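Swapping the amide heteroaryl: thiazole to pyrazole

The source may hold more compounds than are shown below. What is called first, only, known or untested is meant among the compounds shown, and "the series" means these compounds.

Measured compounds:
Compound 1 `COc1ccc(-n2c(SC(C)C(=O)Nc3nc(C)c(Br)cc3Br)nc3ccccc32)cc1` gives 9700 nM in an ADME assay on Vero cells (Chlorocebus sabaeus) for cytotoxicity, read by MTT assay, with a stated time of 24 h; on this read-out lower numbers stand for higher toxicity in this test and higher numbers for lower toxicity in this test.
Compound 2 `COc1ccc(-n2c(SC(C)C(=O)Nc3nc(C)cs3)nc3ccccc32)cc1` gives "not determined" (no result reported) in this assay.

Compound 2 therefore stands without a number on this read-out; the only figure available for the shared core comes from compound 1, which in this assay gives 9700 nM. Compound 3 `COc1ccc(-n2c(SC(C)C(=O)Nc3cc(C)nn3C)nc3ccccc32)cc1` is the next member to be tested. It differs from compound 2 in one place: 1,3-dimethyl-1H-pyrazol-5-yl in place of 4-methyl-1,3-thiazol-2-yl on an amide-type nitrogen. Among the compounds with values here, with no value for compound 2 and no measured step to lean on, there is nothing in the data to suggest a shift in this assay beyond the usual scatter in either direction. On that basis, and taking compound 1 as the only reference point at 9700 nM, compound 3 is expected to give about 10000 nM in this assay, with a plausible range from 3000 nM to 40000 nM.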

Compound 3, half-maximal cytotoxic concentration: 75000 nM
Estimate against measurement, compound 3: 7.5-fold (0.88 log units) below; the measured number lies above the stated range.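

Within the data shown here, on the amide-type nitrogen, 1,3-dimethyl-1H-pyrazol-5-yl in place of 3,5-dibromo-6-methylpyridin-2-yl gives the first readable step in this assay, with a 7.7-fold higher number from compound 1 to compound 3 (0.89 log units; beyond the scatter), which lies beyond the usual scatter and points to lower toxicity in this test. This shows that the group on this nitrogen can move the read-out on the shared core, while the step from compound 2 to compound 3 cannot be read, as compound 2 has no number. Nothing in the available data accounts for the shift.

The compounds shown leave open how much of this step belongs to the pyrazole ring and how much to the two bromine atoms and the methyl group of the group it replaces. They also leave open what a plain pyridin-2-yl group or a pyrazole bearing a carboxylic acid would give on this nitrogen.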